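A few compounds are considered here, and "the series" means these few. Any claim that something is new, unique, unknown or untested is made for them only; others in the source may bear on it.

Three compounds that share one core were tested in a functional assay on CFPAC-1 cells (Homo sapiens) for antiproliferative activity, read by MTT assay, with a stated time of 72 h; a higher number here means a weaker inhibitor, a lower number a stronger inhibitor. Compound 1 `O=C1O[C@H]([C@@H](O)Cn2cc(-c3ccc(Br)cc3)nn2)C(OCc2ccccc2)=C1OCc1ccccc1` gives 5830 nM. Compound 2 `CCCCCc1ccc(-c2cn(C[C@H](O)[C@H]3OC(=O)C(OCc4ccccc4)=C3OCc3ccccc3)nn2)cc1` gives 9890 nM, and the step of a 1.7-fold higher number from compound 1 to compound 2 (0.23 log units; within the scatter) is small. Compound 3 `O=C1O[C@H]([C@@H](O)Cn2cc(CNS(=O)(=O)c3ccc(F)cc3)nn2)C(OCc2ccccc2)=C1OCc1ccccc1` gives 34700 nM, the highest of the three numbers: the step of a 6.0-fold higher number from compound 1 to compound 3 (0.77 log units; beyond the scatter) and the step of a 3.5-fold higher number from compound 2 to compound 3 (0.55 log units; beyond the scatter) both leave compound 3 as the weakest inhibitor among them.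

Compound 4 `CCCCCCCCCCc1cn(C[C@H](O)[C@H]2OC(=O)C(OCc3ccccc3)=C2OCc2ccccc2)nn1` has not yet been measured. It differs from compound 3 by nonyl in place of ((4-fluorophenyl)sulfonyl)amino on a saturated chain carbon bound to an aromatic carbon, so the group on the ring becomes a plain decyl chain. Among the measured compounds shown here, no measured step swaps the sulfonamide for a chain directly; the nearest guide is that both measured departures from the sulfonamide-bearing compound 3, toward compound 1 and toward compound 2, gave lower numbers, and compound 2, which already carries a pentyl chain, sits close to compound 1. A modest lowering is therefore expected, a 2.9-fold lower number from compound 3 to compound 4 (0.46 log units; beyond the scatter). Compound 4 is estimated at 12000 nM, with a range of 4000 nM to 35000 nM.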

Compound 4, half-maximal inhibitory concentration: 40300 nM
Estimate against measurement, compound 4: 3.4-fold (0.53 log units) below; measured number above the stated range.
By their numbers in this assay, from the lowest: compounds 1 and 2 (each within the scatter of the next); then compounds 3 and 4 (each within the scatter of the next).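

In this assay, the step of a 1.2-fold higher number from compound 3 to compound 4 (0.06 log units; within the scatter) shows that this position tolerates a large swap: nonyl in place of ((4-fluorophenyl)sulfonyl)amino on the saturated chain carbon makes no difference beyond the scatter, even though a six-membered aromatic ring, a hydrogen-bond donor and two hydrogen-bond acceptors leave. Decyl on the aromatic carbon gives a 4.1-fold higher number from compound 2 to compound 4 (0.61 log units; beyond the scatter) and a 6.9-fold higher number from compound 1 to compound 4 (0.84 log units; beyond the scatter) so, among these four, the two numbers at the low end belong to the compounds with a substituted phenyl group placed directly on that carbon. No measurement on hand explains these differences.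

A plain phenyl group, a shorter chain such as butyl, or a decyl chain ending in an amine or a carboxylic acid could show which feature matters. Where such groups would fall relative to these four compounds stays open.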